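The compounds below may be only part of what the source reports. "The series", "measured", "known", "first", "only" and "open" are said of these compounds alone.

Measured so far: compound 1 `COc1cc2oc(-c3ccccc3)cc(=O)c2c(O)c1OCCCN1CCCCC1` gives 17000 nM in a functional assay on A549 cells (Homo sapiens) for antiproliferative activity, read by MTT assay, with a stated time of 48 h; a lower number here means a stronger inhibitor, a higher number a weaker inhibitor; compound 2 `COc1cc2oc(-c3ccccc3)cc(=O)c2c(O)c1OCCCCN1CCN(C)CC1` gives 32000 nM; compound 3 `CN1CCN(CCCOc2c(OCc3ccccc3)cc3oc(-c4ccccc4)cc(=O)c3c2O)CC1` gives 1300 nM.

Compound 3 stands lowest of the three numbers, well beyond the scatter from both compound 1 and compound 2. Compound 4 `COc1cc2oc(-c3ccccc3)cc(=O)c2c(O)c1OCCCN1CCN(C)CC1` carries hydrogen in place of phenyl on a saturated chain carbon bound to an oxygen on an aromatic ring, so it keeps the methoxy of compounds 1 and 2 and the amine end of compound 2. Within the data shown here, no measured step covers this change directly; the only measured step, a 1.9-fold higher number from compound 1 to compound 2 (0.27 log units; within the scatter), concerns the amine end and lies within the scatter. Compounds 1 and 2 both sit far above compound 3, which suggests the benzyl group accounts for most of the gap. Compound 4 is therefore expected to move back toward those values, a 15-fold higher number from compound 3 to compound 4 (1.19 log units; beyond the scatter), giving an estimated 20000 nM (range 7000 nM to 55000 nM).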

Compound 4, half-maximal inhibitory concentration: 18000 nM
Estimate against measurement, compound 4: 1.1-fold (0.05 log units) above, and the stated range covers the measured number.
By their numbers in this assay, from the lowest: compound 3; then compounds 1, 4 and 2 (each within the scatter of the next).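

Benzyloxy to methoxy is now a measured single change at this position, and it is large: a 14-fold higher number from compound 3 to compound 4 (1.14 log units; beyond the scatter). The amine end and chain show no such effect, with a 1.1-fold higher number from compound 1 to compound 4 (0.02 log units; within the scatter) for 4-methylpiperazin-1-yl in place of piperidin-1-yl, and a 1.8-fold lower number from compound 2 to compound 4 (0.25 log units; within the scatter) for 4-methylpiperazin-1-yl in place of (4-methylpiperazin-1-yl)methyl. No supporting evidence bears on the origin of the benzyloxy step.

On these data alone, whether the phenyl ring itself is needed remains open. An ethoxy or a 4-fluorobenzyloxy group on the same oxygen would test this.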